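Halogen swap on the fused ring: compound 3 to compound 4

A few compounds are considered here, and "the series" means these few. Any claim that something is new, unique, unknown or untested is made for them only; others in the source may bear on it.

The series keeps one shared core and varies only the aromatic arm attached to it. Compound 1 `CC#CCn1c(N2CCC[C@@H](N)C2)cc(=O)n(Cc2ccccc2)c1=O` is the plain benzyl member. In an assay on isolated protein for inhibition of Dipeptidyl peptidase 9 (Homo sapiens) (a lower number here means a stronger inhibitor, a higher number a weaker inhibitor), compound 1 gives only a limit, > 100000 nM. Compound 2 `CC#CCn1c(N2CCC[C@@H](N)C2)cc(=O)n(Cc2ccc3cc(OC)ccc3n2)c1=O` carries a methoxy on the fused ring system. In this assay compound 2 likewise returns only a limit, > 100000 nM. Compound 3 `CC#CCn1c(N2CCC[C@@H](N)C2)cc(=O)n(Cc2ccc3cc(Cl)ccc3n2)c1=O` carries chloro at the same place. In this assay compound 3 again gives only a limit, > 100000 nM. For the measured compounds named here, the single measured step, a step that the two limits leave unreadable from compound 2 to compound 3, cannot be sized, since the limit of > 100000 nM in this assay, at which 3 of the 3 values shown sit, holds every value so far. Compound 4 `CC#CCn1c(N2CCC[C@@H](N)C2)cc(=O)n(Cc2ccc3cc(Br)ccc3n2)c1=O` is the next member: bromo in place of chloro on an aromatic carbon. Going by the values given here, no measured step bears on this change other than the unreadable one already noted, and with all three values at the limit no shift beyond the scatter is expected in either direction. Compound 4 is therefore expected to sit at the limit too, estimated at 200000 nM with a range from 100000 nM to 1000000 nM. The implied step is expected to be a step that the limit leaves unreadable from compound 3 to compound 4.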

Compound 4, half-maximal inhibitory concentration: > 100000 nM
Compound 4 gave a limit, no number (the forecaster's own chance of this, stated with the estimate: 90%); the middle value does not contradict the limit.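

For the compounds shown here, compound 4, like compound 2 and compound 3, returns only a limit in this assay, so no step among them can be read: the limit of > 100000 nM in this assay, at which 4 of the 4 values shown sit. The compounds shown leave open which aromatic arm on the shared core, if any, gives a measurable value in this assay.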